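Pyrazolidinedione benzylidene series: indolyl replacement at the exocyclic carbon

A few compounds are considered here, and "the series" means these few. Any claim that something is new, unique, unknown or untested is made for them only; others in the source may bear on it.

Measured compounds:
- compound 1 `O=C1C(=Cc2ccc(F)cc2)C(=O)N(c2ccc(Cl)cc2)N1c1ccc(Cl)cc1`: 26000 nM
- compound 2 `COc1cccc(C=C2C(=O)N(c3ccc(Cl)cc3)N(c3ccc(Cl)cc3)C2=O)c1O`: 24300 nM
- compound 3 `COc1ccccc1C=C1C(=O)N(c2ccc(Cl)cc2)N(c2ccc(Cl)cc2)C1=O`: 28600 nM

All three values come from a functional assay on MGC-803 cells (Homo sapiens) for cytotoxicity, read by MTT assay, with a stated time of 72 h; on this read-out higher numbers stand for weaker inhibition and lower numbers for stronger inhibition. Compound 1 stands second highest of the three numbers; its nearest neighbour is compound 2 a 1.1-fold lower number from compound 1 to compound 2 (0.03 log units; within the scatter), its furthest compound 3 a 1.1-fold higher number from compound 1 to compound 3 (0.04 log units; within the scatter), and the step from compound 2 to compound 3 is likewise small a 1.2-fold higher number from compound 2 to compound 3 (0.07 log units; within the scatter). Every change so far at the aryl group on the double-bonded chain carbon has left the read-out in this assay essentially unchanged.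

Compound 4 `O=C1C(=Cc2c[nH]c3ccccc23)C(=O)N(c2ccc(Cl)cc2)N1c1ccc(Cl)cc1` differs from compound 1 as follows: 1H-indol-3-yl in place of 4-fluorophenyl on a double-bonded chain carbon bound to a double-bonded ring carbon. The three measured steps all bear on this position, and none of them reached beyond the scatter. Within the data shown here, no measured step introduces a bicyclic group or a hydrogen-bond donor of this kind, so the data give no direction for the change; the expectation is therefore a step from compound 1 to compound 4 of about a 1.2-fold lower number from compound 1 to compound 4 (0.07 log units; within the scatter) in this assay, not clearly beyond the scatter. Compound 4 is thus estimated at 22000 nM, within a range of 9000 nM to 50000 nM.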

Compound 4, half-maximal inhibitory concentration: 21800 nM
Compound 4: middle estimate off by 1.0-fold (0.00 log units), on the high side; low and high end bracket the measured number.
By their numbers in this assay, from the lowest: compounds 4, 2, 1 and 3 (each within the scatter of the next).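

In this assay the change to 1H-indol-3-yl gives a 1.2-fold lower number from compound 1 to compound 4 (0.08 log units; within the scatter) and also a 1.3-fold lower number from compound 3 to compound 4 (0.12 log units; within the scatter) and a 1.1-fold lower number from compound 2 to compound 4 (0.05 log units; within the scatter) as the comparison with the other two aryl groups. On the double-bonded chain carbon, then, a group with a five-membered aromatic ring and an indole hydrogen-bond donor, a type absent from compounds 1, 2 and 3, still leaves the read-out within the scatter, so the flat picture now extends beyond substituted phenyl groups. Nothing available accounts for this flat response.

On these data alone, whether an amine, a carboxylic acid or a longer chain at this position would move the number beyond the scatter stays open. Also open, as far as these compounds go, is how far the shared core, unchanged across all four compounds, governs the read-out.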